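The source may report more compounds than this note shows. Statements on the series, on what has been measured and on what is new or still open speak of the compounds shown alone.

Measured so far in an assay for inhibition of Fatty-acid amide hydrolase 1 (Rattus norvegicus); a lower number here means a stronger inhibitor, a higher number a weaker inhibitor:
Compound 1 `CCCCCCCCCC(=O)C(F)(F)F`: 600 nM
Compound 2 `CCCCCCC(=O)C(F)(F)F`: 52800 nM

Compound 2 stands at the higher of these two numbers, so it is the weaker inhibitor of the pair. For the measured compounds named here, the single measured step, an 88-fold higher number from compound 1 to compound 2 (1.94 log units; beyond the scatter), shows that cutting three carbons from the end of the chain costs a great deal of potency. Compound 3 `CCCCCC(=O)C(F)(F)F` continues in the same direction: it differs from compound 2 by hydrogen in place of methyl on a saturated chain carbon, five bonds along the chain from a carbonyl carbon. Going by the values given here, only that one step bears on this change, and it was large, though it removed three carbons where here only one leaves. A further weakening in this assay is therefore expected, smaller than the measured step but beyond the scatter. The step from compound 2 to compound 3 is estimated as a 3.8-fold higher number from compound 2 to compound 3 (0.58 log units; beyond the scatter). Compound 3 is thus expected to give about 200000 nM, within a range of 60000 nM to 600000 nM.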

Compound 3, half-maximal inhibitory concentration: 185000 nM
Compound 3: middle estimate off by 1.1-fold (0.03 log units), on the high side; measured number inside the range.
By their numbers in this assay, from the lowest: compound 1; then compound 2; then compound 3.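

In this assay, removing even one carbon still matters: with hydrogen in place of methyl, five bonds along the chain from a carbonyl carbon, there is a 3.5-fold higher number from compound 2 to compound 3 (0.54 log units; beyond the scatter), a modest step but one beyond the scatter. Until now only the large loss on removing propyl had been seen, so this shows that potency keeps falling as the chain gets shorter, and the whole shortening from the longest chain amounts to a 310-fold higher number from compound 1 to compound 3 (2.49 log units; beyond the scatter), with none of the three compounds going against that order. Nothing available here explains why chain length has this effect.

On these data alone, whether a longer chain than that of compound 1 would lower the number further remains open. Also open, as far as these compounds go, is how the series would respond to a benzene ring at the chain end, or to a carboxylic acid in place of the trifluoromethyl carbonyl end.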